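The source may hold more compounds than are shown below. What is called first, only, known or untested is meant among the compounds shown, and "the series" means these compounds.

In a functional assay on HCT-8 cells (Homo sapiens) for antiproliferative activity, read by MTT assay, with a stated time of 48 h (a lower number here means a stronger inhibitor, a higher number a weaker inhibitor), compound 2 `COc1cc(C(=O)/C=C/c2c[nH]c3ccccc23)cc([N+](=O)[O-])c1OC` gives 1390 nM. That lies within the scatter of compound 1 `COc1ccc2c(/C=C/C(=O)c3cc(OC)c(OC)c([N+](=O)[O-])c3)c[nH]c2c1`, which gives 982 nM, whereas compound 3 `COc1cc(C(=O)/C=C/c2c[nH]c3ccccc23)cc(SC)c1OC` gives a clearly lower 167 nM. The unmeasured compound 4 `COc1cc(C(=O)/C=C/c2cn(C)c3ccccc23)cc([N+](=O)[O-])c1OC` alters compound 2 at one place: methyl in place of hydrogen on an aromatic nitrogen. Neither measured step touches that nitrogen. The step of a 1.4-fold higher number from compound 1 to compound 2 (0.15 log units; within the scatter) comes with hydrogen in place of methoxy on an aromatic carbon, and the step of an 8.3-fold lower number from compound 2 to compound 3 (0.92 log units; beyond the scatter) comes with methylsulfanyl in place of nitro. Among the compounds with values here, with no direct precedent, no shift beyond the scatter is expected, and the estimated step is a 1.4-fold lower number from compound 2 to compound 4 (0.14 log units; within the scatter). For compound 4, the estimated value is 1000 nM, with an expected range from 300 nM to 3000 nM.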

Compound 4, half-maximal inhibitory concentration: 1660 nM
For compound 4 the middle estimate is 1.7-fold (0.22 log units) below the measured one; the measured number falls inside the stated range.
By their numbers in this assay, from the lowest: compound 3; then compounds 1, 2 and 4 (each within the scatter of the next).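

In this assay, methyl in place of hydrogen on the aromatic nitrogen gives a 1.2-fold higher number from compound 2 to compound 4 (0.08 log units; within the scatter) and so stays within the usual scatter. Within the data shown here, the earlier steps changed only groups on aromatic carbons, so this is the first sign that this nitrogen accepts a methyl without a clear shift, at least in the nitro-bearing compound 2. No measurement shown accounts for this result.

From the compounds shown here alone, whether a longer chain, an acetyl group or a chain ending in an amine would be accepted on this nitrogen remains open. So does whether methyl would behave the same way in compound 3.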